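A few compounds are considered here, and "the series" means these few. Any claim that something is new, unique, unknown or untested is made for them only; others in the source may bear on it.

Of the compounds shown here, three sharing one core have been tested in a functional assay on CCRF-CEM cells (Homo sapiens) for antiproliferative activity; a lower number here means a stronger inhibitor, a higher number a weaker inhibitor. Compound 1 `COc1cc(C(=O)c2sc(-c3ccc(C)cc3)cc2N)cc(OC)c1OC` gives 15 nM. Among the measured compounds shown here, compound 2 `COc1cc(C(=O)c2sc(-c3ccc(C(F)(F)F)cc3)cc2N)cc(OC)c1OC` gives 270 nM, and the single change of an 18-fold higher number from compound 1 to compound 2 (1.26 log units; beyond the scatter). Compound 3 `COc1cc(C(=O)c2sc(-c3ccncc3)cc2N)cc(OC)c1OC` gives 110 nM; it stands second highest of the three numbers, nearer to compound 2 than to compound 1, since a 2.5-fold lower number from compound 2 to compound 3 (0.39 log units; beyond the scatter) while a 7.3-fold higher number from compound 1 to compound 3 (0.87 log units; beyond the scatter).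

Compound 4 `COc1ccc(-c2cc(N)c(C(=O)c3cc(OC)c(OC)c(OC)c3)s2)cc1` is not yet measured in this assay. It differs from compound 3 in one place: 4-methoxyphenyl in place of pyridin-4-yl on an aromatic carbon. The step that bears most directly on this change is the one in which a 7.3-fold higher number from compound 1 to compound 3 (0.87 log units; beyond the scatter), since compound 4 reverses the move from a carbon-only ring toward pyridin-4-yl, now with 4-methoxyphenyl entering. The step in which an 18-fold higher number from compound 1 to compound 2 (1.26 log units; beyond the scatter) shows that the group on that ring matters greatly, and that a trifluoromethyl group costs far more than a methyl. A methoxy group is neither of these, so the expectation rests on the reversal of the pyridin-4-yl step alone. Compound 4 is therefore expected to show a lower number than compound 3, with a 4.4-fold lower number from compound 3 to compound 4 (0.64 log units; beyond the scatter). The estimate for compound 4 in this assay is 25 nM, expected to lie between 8 nM and 80 nM.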

Compound 4, half-maximal inhibitory concentration: 19 nM
Compound 4: middle estimate off by 1.3-fold (0.12 log units), on the high side; the range from low to high includes it.
By their numbers in this assay, from the lowest: compounds 1 and 4 (each within the scatter of the next); then compound 3; then compound 2.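

Among the compounds shown here, at this position, on the aromatic carbon next to the ring sulfur, the methyl of compound 1 is not the only group on the phenyl ring compatible with a low number in this assay: with a 1.3-fold higher number from compound 1 to compound 4 (0.10 log units; within the scatter), methoxy and methyl cannot be told apart. The loss seen with pyridin-4-yl is now shown to be recovered by a second carbon-only ring, with a 5.8-fold lower number from compound 3 to compound 4 (0.76 log units; beyond the scatter), so the earlier comparison no longer rests on compound 1 alone. Trifluoromethyl also stands apart from two groups rather than one, with a 14-fold lower number from compound 2 to compound 4 (1.15 log units; beyond the scatter), a large step like the one already seen from methyl. Nothing in the data given here explains these differences.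

The compounds shown leave open whether an ethoxy group, a hydroxyl, a chlorine or a dimethylamino group on the same ring would stay level with methyl and methoxy or move towards trifluoromethyl. They also leave open whether methoxy would behave alike on another carbon of that ring, since all the substituted phenyl rings here carry a single group in the same place.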